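Replacing the methylsulfonyl group on a shared core

The source may hold more compounds than are shown below. What is called first, only, known or untested is meant among the compounds shown, and "the series" means these compounds.

Measured compounds:
compound 1, `CC(C)c1n[nH]c2c(NCc3ccc(-c4ccccn4)cc3)nc(S(C)(=O)=O)nc12`, 640 nM
compound 2, `CC(C)c1n[nH]c2c(NCc3ccc(-c4ccccn4)cc3)nc(NCC(N)CO)nc12`, 700 nM

In a functional assay on K562 cells (Homo sapiens) for cytotoxicity, read by fluorescence, with a stated time of 72 h (on this read-out lower numbers stand for stronger inhibition and higher numbers for weaker inhibition), compound 1 gives 640 nM, the lowest of the two numbers; compound 2 gives 700 nM, and the step of a 1.1-fold higher number from compound 1 to compound 2 (0.04 log units; within the scatter) lies within the scatter. Compound 3, `COc1ccc(CNc2nc(NCc3ccc(-c4ccccn4)cc3)c3[nH]nc(C(C)C)c3n2)cc1`, has not yet been measured. It differs from compound 1 by (4-methoxybenzyl)amino in place of methylsulfonyl on an aromatic carbon. Going by the values given here, the only measured step that bears on this is the step from compound 1 to compound 2, where the same methylsulfonyl leaves and a different group enters, with a 1.1-fold higher number from compound 1 to compound 2 (0.04 log units; within the scatter). Among the compounds with values here, that step was within the scatter, so no shift beyond the scatter is expected from this second replacement either, although the entering group here differs from the one in compound 2. Compound 3 is therefore expected to give about 550 nM in this assay, within a range of 180 nM to 1700 nM, which corresponds to an estimated step of a 1.2-fold lower number from compound 1 to compound 3 (0.07 log units; within the scatter).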

Compound 3, half-maximal inhibitory concentration: 3950 nM
Estimate against measurement, compound 3: 7.2-fold (0.86 log units) below; measured number above the stated range.
By their numbers in this assay, from the lowest: compounds 1 and 2 (each within the scatter of the next); then compound 3.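

In this assay the position on the aromatic carbon between two ring nitrogen atoms does not treat every replacement of methylsulfonyl alike: (4-methoxybenzyl)amino brings a 6.2-fold higher number from compound 1 to compound 3 (0.79 log units; beyond the scatter), a shift beyond the scatter. Set against the 1-amino-2-hydroxyethyl side chain, the 4-methoxyphenyl end of the new group brings a 5.6-fold higher number from compound 2 to compound 3 (0.75 log units; beyond the scatter), so the group placed here can move the number, which a 1.1-fold higher number from compound 1 to compound 2 (0.04 log units; within the scatter) alone could not show. Nothing available here explains this rise.

On these data alone, it remains open whether the rise follows the six-membered aromatic ring or the methoxy group, which a plain benzylamino group without the methoxy would separate. As far as these compounds go, it is equally open whether a small amine such as methylamino, or a morpholine, would stay close to compound 1.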